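The source may report more compounds than this note shows. Statements on the series, on what has been measured and on what is new or still open speak of the compounds shown alone.

Compound 1, `CCCc1cc(N)c2cc(NC(=O)c3ccc(-c4ccc(Cl)cc4)cc3)ccc2n1`: 75 nM
Compound 2, `CCCc1cc(N)c2cc(NC(=O)/C=C/c3ccc(Cl)cc3)ccc2n1`: 96 nM

Both were tested in a functional assay on HEK293 cells for activation of melanin-concentrating hormone receptor 1 (Homo sapiens), read by inositol phosphate accumulation; on this read-out higher numbers stand for an effect only at larger amounts of compound and lower numbers for an effect already at smaller amounts. Compound 1 gives 75 nM, and compound 2 gives 96 nM; the gap between them lies within the usual scatter, so the two cannot be told apart. Compound 3 `CCCc1cc(N)c2cc(NC(=O)c3ccc(-c4ccc(C(F)(F)F)cc4)cc3)ccc2n1` has not yet been measured. It differs from compound 1 by trifluoromethyl in place of chloro on an aromatic carbon. Within the data shown here, no measured pair shows this exact swap, so there is no direct guide; since both groups carry no donors, no acceptors and no charge, the step is expected to stay within the scatter. Compound 3 is estimated at 100 nM, between 35 nM and 300 nM, which means an expected step of a 1.3-fold higher number from compound 1 to compound 3 (0.12 log units; within the scatter).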

Compound 3, half-maximal effective concentration: 310 nM
The estimate for compound 3 lay 3.1-fold (0.49 log units) below the measured number, outside the stated range (above it).
By their numbers in this assay, from the lowest: compounds 1 and 2 (each within the scatter of the next); then compound 3.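

In this assay this aromatic carbon proves sensitive to the group it carries: trifluoromethyl in place of chloro gives a 4.1-fold higher number from compound 1 to compound 3 (0.62 log units; beyond the scatter), a step beyond the scatter. Neither group has hydrogen-bond donors, hydrogen-bond acceptors or a net charge, so a change at this position can matter even when those counts stay the same. Nothing available here explains the step.

The compounds shown leave open how fluoro, methyl, methoxy or nitrile would behave at this position. They also do not show whether plain hydrogen there would match chloro or trifluoromethyl.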